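Trading a large aromatic group for a hydroxy on the piperidine

The source may hold more compounds than are shown below. What is called first, only, known or untested is meant among the compounds shown, and "the series" means these compounds.

Compound 1: `CCCCNc1nc(C(F)(F)F)ccc1CNC(=O)C(C)c1ccc(NS(C)(=O)=O)c(F)c1` — 9.1 nM
Compound 2: `CC1CCC(Nc2nc(C(F)(F)F)ccc2CNC(=O)C(C)c2ccc(NS(C)(=O)=O)c(F)c2)CC1` — 27.2 nM
Compound 3: `Cc1ccc(CC2CCN(c3nc(C(F)(F)F)ccc3CNC(=O)C(C)c3ccc(NS(C)(=O)=O)c(F)c3)CC2)cc1` — 0.2 nM

All three compounds were measured in a functional assay on CHO-K1 cells for antagonist activity at transient receptor potential cation channel subfamily V member 1 (Homo sapiens), read by FLIPR; a lower number here means a stronger inhibitor, a higher number a weaker inhibitor. Compound 3 stands lowest of the three numbers, and its gaps to compound 1 and compound 2 are both well beyond the usual scatter, so it is the strongest inhibitor of this set. Going by the values given here, the one measured step with a single change, a 3.0-fold higher number from compound 1 to compound 2 (0.48 log units; beyond the scatter), is only modest in size.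

Compound 4 is `CC(C(=O)NCc1ccc(C(F)(F)F)nc1N1CCC(O)CC1)c1ccc(NS(C)(=O)=O)c(F)c1`. It differs from compound 3 in one place: hydroxy in place of 4-methylbenzyl on a saturated ring carbon. Among the compounds with values here, no measured step involves this kind of change; the step from compound 1 to compound 2 exchanges one non-aromatic group for another and says little about removing the whole 4-methylbenzyl. What the data do show is that compound 3, which carries that group, sits far below compound 1 and compound 2, which lack it, so its loss is expected to cost potency in this assay, probably by more than a small step. Compound 4 is therefore expected to lie near 20 nM, within 3 nM to 150 nM, which corresponds to an expected rise of a 100-fold higher number from compound 3 to compound 4 (2.00 log units; beyond the scatter).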

Compound 4, inhibition constant: "not active" (no number reported)
No number was reported for compound 4; the estimate stays without a comparison.
By their numbers in this assay, from the lowest: compound 3; then compound 1; then compound 2.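

Going by these compounds alone, compound 4 is reported as "not active" in this assay, without a number, so no step from compound 3 to compound 4 can be read. No supporting data bear on why this result arose. The compounds shown leave open whether the outcome comes from losing the 4-methylbenzyl or from gaining the hydroxy.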